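The compounds below may be only part of what the source reports. "The series", "measured", "known", "first", "only" and "open" are said of these compounds alone.

Measured in a functional assay on HEK293 cells for agonist activity at G-protein coupled receptor 39 (Homo sapiens), read by scintillation proximity assay and inositol phosphate accumulation, with a stated time of 75 min, in the presence of a further agent that is not named here; on this read-out lower numbers stand for an effect already at smaller amounts and higher numbers for an effect only at larger amounts of compound:

Compound 1 `Cc1nn(-c2ncnc3nc[nH]c23)c2c1C(OC1CCCC1)CC(=O)N2` gives 2 nM.
Compound 2 `CCCCCCCCOC1CC(=O)Nc2c1c(C)nn2-c1ncnc2nc[nH]c12` gives 8 nM.
Compound 3 `Cc1nn(-c2ncnc3nc[nH]c23)c2c1C(OCc1ccc(C#N)cc1)CC(=O)N2` gives 4 nM.

Compound 1 has the lowest of the three numbers. Its nearest neighbour is compound 3, with a 2.0-fold higher number from compound 1 to compound 3 (0.30 log units; within the scatter), which is within the scatter and so tells nothing about order; the step of a 4.0-fold higher number from compound 1 to compound 2 (0.60 log units; beyond the scatter) is beyond the scatter and marks compound 2 as the one that needs the larger amount.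

The unmeasured compound 4 `Cc1nn(-c2ncnc3nc[nH]c23)c2c1C(NC(=O)Cc1cccs1)CC(=O)N2` differs from compound 1 in one place: (((thiophen-2-yl)methyl)carbonyl)amino in place of cyclopentyloxy on a saturated ring carbon. The two measured steps from compound 1 keep the oxygen on the saturated carbon and only swap the group hanging from it; both gave higher numbers, one within the scatter, one modestly beyond it. For the measured compounds named here, in compound 4 the oxygen itself is gone and an amide with a hydrogen-bond donor enters, a change for which no measured step exists, so the guidance is indirect. Going by the values given here, since every exchange at this position so far has moved the number upward, compound 4 is expected to show a moderate rise in this assay, around a 4.0-fold higher number from compound 1 to compound 4 (0.60 log units; beyond the scatter), with a broad range. Compound 4 is therefore estimated at 8 nM, expected to lie between 2 nM and 40 nM.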

Compound 4, half-maximal effective concentration: 3 nM
Compound 4: the middle estimate sits 2.7-fold (0.43 log units) above what was measured, within the range that was stated.
By their numbers in this assay, from the lowest: compounds 1, 4, 3 and 2 (each within the scatter of the next, the first and the last beyond it).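

For the compounds shown here, compound 4 is the first of the compounds here without an oxygen on this saturated ring carbon, and in this assay the exchange of cyclopentyloxy for (((thiophen-2-yl)methyl)carbonyl)amino gives a 1.5-fold higher number from compound 1 to compound 4 (0.18 log units; within the scatter), so this amide, with the hydrogen-bond donor it brings, can stand in place of the ether without a step that can be told from the scatter. Going by these compounds alone, the comparison with the (4-cyanobenzyl)oxy group reads the same way, with a 1.3-fold lower number from compound 3 to compound 4 (0.12 log units; within the scatter), whereas the comparison with octyloxy gives a 2.7-fold lower number from compound 2 to compound 4 (0.43 log units; beyond the scatter), a modest step that is beyond the scatter and places the octyl ether as the one compound of this pair that needs the larger amount. No separate measurement accompanies these results to say why the amide and the ethers lie so close.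

On these data alone, with one amide in hand, it remains open whether the amide hydrogen or the thiophene ring contributes anything, which an N-methyl amide or a phenylacetyl amide at this carbon could test. As far as these compounds go, it also remains open how far this carbon accepts other kinds of group, such as a free amine, a carboxylic acid or a sulfonamide.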